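Swapping 4-fluorophenyl for 2-(trifluoromethyl)phenyl

The source may hold more compounds than are shown below. What is called first, only, known or untested is meant among the compounds shown, and "the series" means these compounds.

In an ADME assay on HEK293 cells (Homo sapiens) for cytotoxicity, read by MTT assay, with a stated time of 24 h (on this read-out lower numbers stand for stronger inhibition and higher numbers for weaker inhibition), compound 2 `CN(C)CCCNc1nc2cc([N+](=O)[O-])ccc2nc1NCc1ccc(F)cc1` gives 4.28 ug/mL and compound 1 `CN(C)CCCNc1nc2cc([N+](=O)[O-])ccc2nc1NCc1ccc(C(F)(F)F)cc1` gives 5.66 ug/mL, values within the scatter of each other. Compound 3 `CN(C)CCCNc1nc2cc([N+](=O)[O-])ccc2nc1NCc1ccccc1C(F)(F)F` has 2-(trifluoromethyl)phenyl in place of 4-fluorophenyl on a saturated chain carbon bound to a nitrogen on an aromatic ring. Within the data shown here, one measured step bears on this: a 1.3-fold lower number from compound 1 to compound 2 (0.12 log units; within the scatter), with fluoro in place of trifluoromethyl on an aromatic carbon. Among the measured compounds shown here, no measured compound carries the entering group, so nothing beyond the scatter is expected in this assay. The estimated step is a 1.2-fold higher number from compound 2 to compound 3 (0.07 log units; within the scatter). Compound 3 is expected at 5 ug/mL, within a range of 2.5 ug/mL to 10 ug/mL.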

Compound 3, half-maximal inhibitory concentration: 24.7 ug/mL
Compound 3: middle estimate off by 4.9-fold (0.69 log units), on the low side; measured number above the stated range.
By their numbers in this assay, from the lowest: compounds 2 and 1 (each within the scatter of the next); then compound 3.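

In this assay the group on this saturated chain carbon turns out to matter, with a step of a 4.4-fold higher number from compound 1 to compound 3 (0.64 log units; beyond the scatter) when only the trifluoromethyl's place on the phenyl ring differs. Against 4-fluorophenyl, the step is a 5.8-fold higher number from compound 2 to compound 3 (0.76 log units; beyond the scatter). The earlier pair showed no step beyond the scatter, so compound 3 gives the first sign of sensitivity here, and nothing available explains it. On these data alone, whether a chloro or a methoxy group in the place of that trifluoromethyl would give a similar rise stays open.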